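One chloro fewer: from compound 2 to compound 3

The source may report more compounds than this note shows. Statements on the series, on what has been measured and on what is new or still open speak of the compounds shown alone.

Compound 1 `CC(C)(C)NCc1c(C(=O)O)nn(-c2ccccc2)c1-c1ccccc1` - > 716000 nM (a limit of the assay, not a number)
Compound 2 `CC(C)(C)NCc1c(C(=O)O)nn(-c2ccc(Cl)cc2)c1-c1ccc(Cl)cc1` - 87500 nM

Among the compounds with values here, in an ADME assay on HaCaT cells (Homo sapiens) for inhibition, read by sulforhodamine B assay, with a stated time of 48 h (on this read-out higher numbers stand for weaker inhibition of growth and lower numbers for stronger inhibition of growth), compound 2 gives 87500 nM, and this is the only exact number so far. The other measured compound offers no second number to rank it against.

The next compound to be tested is compound 3 `CC(C)(C)NCc1c(C(=O)O)nn(-c2ccc(Cl)cc2)c1-c1ccccc1`. It differs from compound 2 in a single place: hydrogen in place of chloro on an aromatic carbon. In plain terms, hydrogen stands in place of chloro on an aromatic carbon, so that a 4-chlorophenyl becomes a phenyl.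

Within the data shown here, no measured pair shows this change on its own, so any forecast is uncertain. The best available guide is compound 1, whose > 716000 nM is a limit of the assay. With that limit on the weaker side, a shift towards weaker inhibition of growth seems more likely than a shift towards stronger inhibition. An estimated 2.5-fold higher number from compound 2 to compound 3 (0.40 log units; beyond the scatter) in this assay would be a modest move, close to the usual scatter or a little past it. For compound 3 the expected value is 220000 nM, with an estimated range from 90000 nM to 600000 nM.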

Compound 3, concentration for 50% growth inhibition: 175000 nM
Compound 3: middle estimate off by 1.3-fold (0.10 log units), on the high side; measured number inside the range.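

In this assay, turning one of the two 4-chlorophenyl groups into a phenyl gives a 2.0-fold higher number from compound 2 to compound 3 (0.30 log units; within the scatter), so at this place the loss of a chloro cannot be told apart from the ordinary spread of repeated measurements. The other chloro tells a different story: placing it on a phenyl of the core with no chloro at all gives an at least 4.0-fold lower number from compound 1 to compound 3 (0.61 log units; beyond the scatter), so one chloro already marks a clear step, while the second adds nothing that can be separated from that spread. The size of this larger step is open-ended, since the reading for compound 1 is a limit of the assay and not a number: the limit of > 716000 nM in this assay, at which 1 of the 3 values shown sits.

From the compounds shown here alone, whether a fluoro, a methyl or a methoxy at this same place would read like the chloro or like the hydrogen remains open, and so does whether the single chloro would count the same on the other phenyl. The compounds shown also say nothing about how growth inhibition would respond if an amide stood in place of the carboxylic acid.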